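The source may report more compounds than this note shows. Statements on the series, on what has been measured and on what is new or still open speak of the compounds shown alone.

Measured so far:
compound 1 `CCCCCCc1cc2cn(COCCO)c(O)nc-2n1` — > 400000 nM
compound 2 `CCCCCCCCCCc1cc2cn(COCCO)c(O)nc-2n1` — 80000 nM

Within the data shown here, in a functional assay on HEL cells (Homo sapiens), read by microscopy (on this read-out higher numbers stand for lower toxicity in this test and lower numbers for higher toxicity in this test), compound 2 gives 80000 nM, the only number in the set. For compound 1 the read-out is a limit of the assay, > 400000 nM (the limit of > 400000 nM in this assay, at which 1 of the 2 values shown sits). Among the measured compounds shown here, the one measured step, an at least 5.0-fold lower number from compound 1 to compound 2 (0.69 log units; beyond the scatter), runs from that limit to the number of compound 2.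

Compound 3 `CCCCCCCc1cc2cn(COCCO)c(O)nc-2n1` has not yet been measured. It differs from compound 2 by hydrogen in place of propyl on a saturated chain carbon, seven bonds along the chain from an aromatic carbon. The change runs the same chain back in the direction of compound 1, shortening it by less than the step from compound 1 to compound 2 lengthened it. For the measured compounds named here, the only step that bears on it is an at least 5.0-fold lower number from compound 1 to compound 2 (0.69 log units; beyond the scatter); read in reverse and for a smaller cut, a rise in the number toward the limit is expected, beyond the scatter but not necessarily all the way to the limit. Compound 3 is therefore expected to give 250000 nM in this assay, between 100000 nM and 600000 nM. The step this estimate means is a 3.1-fold higher number from compound 2 to compound 3 (0.49 log units; beyond the scatter). A limit rather than a number is a real possibility here.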

Compound 3, minimum cytotoxic concentration: >= 400000 nM
Compound 3 was reported as a limit; the forecaster's own chance of this, stated with the estimate: 45%; at least 1.6-fold (0.20 log units) between middle value and limit.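

In this assay, hydrogen in place of propyl on a saturated chain carbon, seven bonds along the chain from an aromatic carbon, gives an at least 5.0-fold higher number from compound 2 to compound 3 (0.69 log units; beyond the scatter), so the lower number of compound 2 is not kept once the chain is cut back to that of compound 3. Among these compounds, compound 3 is reported only as a limit, >= 400000 nM, which leaves compound 2 as the only compound in this short series with a number, and places the appearance of a number somewhere along the stretch of chain that separates compound 3 from compound 2. The step from compound 1 to compound 3 cannot be read, as both values are limits: the limit of >= 400000 nM in this assay, at which 1 of the 3 values shown sits.

On these data alone, how the number moves for chains of intermediate length, and whether the rise in toxicity sets in gradually or abruptly, stays open. Also open, as far as these compounds go, are whether a longer chain than that of compound 2 lowers the number further in this assay, and whether an amine or a carboxylic acid at the end of the chain of compound 2 keeps its number.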